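Swapping fluoro for methoxy at the far aromatic ring

This account rests on a few compounds, and the source may have more. Where it says the series, first, only, none or still open, it means among the compounds named here.

Of the compounds shown here, three have been measured in an in vitro functional assay on HEK293 cells for antagonist activity at melanin-concentrating hormone receptor 1 (Homo sapiens); on this read-out lower numbers stand for smaller maximal responses and higher numbers for larger maximal responses. Compound 1 `Cc1ccc(CN2CCC(NC(=O)N(CC(=O)C(C)(C)O)Cc3ccc(-c4ccc(F)cc4)cc3)CC2)cc1` gives 79% in this assay. Compound 2 `COc1ccccc1-c1ccc(CN(CC(=O)C(C)(C)O)C(=O)NC2CCN(Cc3ccc(C)cc3)CC2)cc1` gives 68.3%, and the change from compound 1 to compound 2 — 2-methoxyphenyl in place of 4-fluorophenyl on an aromatic carbon — is a number 10.7 percentage points lower from compound 1 to compound 2 (beyond the scatter). Compound 3 `Cc1ccc(CN2CCC(CCN(Cc3ccc(-c4ccc(F)cc4)cc3)C(=O)NC(C)C)CC2)cc1` gives 113%, the highest of the three numbers; its nearest neighbour is compound 1, with compound 2 furthest away.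

Compound 4 `COc1ccc(-c2ccc(CN(CCC3CCN(Cc4ccc(C)cc4)CC3)C(=O)NC(C)C)cc2)cc1` has not yet been measured. It differs from compound 3 in one place: methoxy in place of fluoro on an aromatic carbon. Among the compounds with values here, the only measured step that bears on this is the one from compound 1 to compound 2, which also brought a methoxy group onto the far aromatic ring in place of a fluoro and gave a modest drop. That step was taken on a different core and with the methoxy at a different position, so it is a loose guide. A small decrease, or none beyond the scatter, is therefore expected, with the step from compound 3 to compound 4 estimated as a number 9 percentage points lower from compound 3 to compound 4 (within the scatter). Compound 4 is expected to give about 104% in this assay, in a range from 86% to 122%.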

Compound 4, largest response reached (reported as Imax), in percent of the reference or control that the assay uses: 91.5%
Beside the measured number, compound 4's estimate is 12.5 percentage points above it, and the stated range covers the measured number.
By their numbers in this assay, from the lowest: compound 2; then compound 1; then compound 4; then compound 3.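

In this assay, going from 4-fluorophenyl to 4-methoxyphenyl gives a number 21.5 percentage points lower from compound 3 to compound 4 (beyond the scatter) and so shows a drop from this swap alone, with the group kept in one place on the ring, para to a large group. The earlier step changed the group's place as well as the group, and it was read on the core of compound 1, so a fall at this ring now also appears on the core of compound 3. Nothing measured here accounts for the size of this drop.

As far as these compounds go, whether 2-methoxyphenyl would lower the number further on the core of compound 3 remains open, so the roles of position and group are still not separated on one core. From the compounds shown here alone, it is also open how other groups at this place, such as a chloro, a hydroxyl or an amine, would compare with fluoro and methoxy.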